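A few compounds are considered here, and "the series" means these few. Any claim that something is new, unique, unknown or untested is made for them only; others in the source may bear on it.

Measured compounds:
compound 1 `CC(C)N1CCN(c2cccc3c2C[C@H](CN(C)[C@H]2CCCc4cccnc42)NC3)CC1`: > 30000 nM
compound 2 `CN(C[C@H]1Cc2c(cccc2N2CCN3CCC[C@@H]3C2)CN1)[C@H]1CCCc2cccnc21`: > 30000 nM

In a functional assay on CCRF-CEM cells for agonist activity at C-X-C chemokine receptor type 4 (Homo sapiens), read by calcium flux, with a stated time of 25 min (a lower number here means that less compound is needed, a higher number that more compound is needed for the effect), compound 1 gives > 30000 nM, which is a limit of the assay and not a number. Compound 2 in this assay gives > 30000 nM, likewise a limit. The step that the two limits leave unreadable from compound 1 to compound 2 therefore cannot be read. Within the data shown here, compound 1 thus stands at the limit, as does the one further value shown (the limit of > 30000 nM in this assay, at which 2 of the 2 values shown sit). Compound 3 `CN(C[C@H]1Cc2c(cccc2N2CCN(c3ncccn3)CC2)CN1)[C@H]1CCCc2cccnc21` differs from compound 1 by pyrimidin-2-yl in place of isopropyl on an amine nitrogen in a ring. Among the measured compounds shown here, no measured step bears on this change: the only step, from compound 1 to compound 2, exchanges a different part of the structure and is unreadable in any case. With both measured values at the limit, compound 3 is expected to remain near the limit as well, so the estimated step of an at least 1.2-fold lower number from compound 1 to compound 3 (0.07 log units; that floor lies within the scatter) is small and its direction open. The estimate for compound 3 in this assay is 25000 nM, with a range from 4000 nM to 100000 nM.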

Compound 3, half-maximal effective concentration: > 30000 nM
Compound 3 ended at the assay's limit (the forecaster's own chance of this, stated with the estimate: 75%); at least 1.2-fold (0.07 log units) between middle value and limit.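

In this assay compound 3 gives > 30000 nM, a limit and not a number. Compound 1, compound 2 and compound 3 all sit at this limit, so no step among them can be read: the limit of > 30000 nM in this assay, at which 3 of the 3 values shown sit.

The compounds shown leave open which change to the shared core, if any, would give a value that can be read as a number.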